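The compounds below may be only part of what the source reports. "The series", "measured", "known", "first", "only" and "open" are said of these compounds alone.

Working notes on the phenyl ether series. The shared core is carried by compound 1 `Cc1[nH]c(=O)n(C)c1-c1ccc(OCCC(C)C)cc1`, which in a functional assay on brain (Rattus norvegicus, strain Wistar) for inhibition (on this read-out lower numbers stand for stronger inhibition and higher numbers for weaker inhibition), gives 6600 nM. Compound 2 `Cc1[nH]c(=O)n(C2CCCCC2)c1-c1ccc(OCCC(C)C)cc1` keeps that core and gives 7200 nM in this assay; the step of a 1.1-fold higher number from compound 1 to compound 2 (0.04 log units; within the scatter) shows the swap on the aromatic nitrogen leaving the number essentially unchanged. Compound 3 `CCCCCCCCCCCCOc1ccc(-c2c(C)[nH]c(=O)n2C2CCCCC2)cc1` gives 52400 nM, and the step of a 7.3-fold higher number from compound 2 to compound 3 (0.86 log units; beyond the scatter) is the only clear movement in the set so far. Among the three measured numbers compound 2 stands second highest, within the scatter of compound 1 and well apart from compound 3.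

Compound 4 `Cc1[nH]c(=O)n(C2CCCCC2)c1-c1ccc(OCc2ccccc2)cc1` is the next to be measured. It differs from compound 2 by phenyl in place of isobutyl on a saturated chain carbon bound to an oxygen on an aromatic ring. Among the measured compounds shown here, no measured step changes this position in the same way; the step from compound 2 to compound 3 is the nearest comparison, but it lengthens the chain by a decyl in place of an isopropyl rather than closing a ring. That step says a larger group at the ether weakens inhibition, while the phenyl here adds only two heavy atoms more than the isobutyl it replaces. For compound 4 the expected step is therefore small, a 1.3-fold higher number from compound 2 to compound 4 (0.12 log units; within the scatter), toward a slightly higher number. Compound 4 is estimated at 9500 nM, with a range from 3000 nM to 30000 nM.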

Compound 4, half-maximal inhibitory concentration: 8300 nM
Compound 4: the middle estimate sits 1.1-fold (0.06 log units) above what was measured; low and high end bracket the measured number.
By their numbers in this assay, from the lowest: compounds 1, 2 and 4 (each within the scatter of the next); then compound 3.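

In this assay, the ether position of the cyclohexyl compounds accepts an aromatic ring with no clear effect on the number: a 1.2-fold higher number from compound 2 to compound 4 (0.06 log units; within the scatter), which places phenyl in place of isobutyl on a saturated chain carbon bound to an oxygen on an aromatic ring within the scatter. Among the compounds shown here, the only earlier change at this position was the one to the long chain of compound 3, a 7.3-fold higher number from compound 2 to compound 3 (0.86 log units; beyond the scatter), and that step alone could be read as any larger group here weakening inhibition. For the compounds shown here, compound 4 goes against that reading: isopentyloxy to benzyloxy brings more heavy atoms and a six-membered aromatic ring, yet compound 2 and compound 4 cannot be told apart, so the weaker number so far belongs to compound 3 alone.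

Nothing on hand accounts for the benzyloxy and isopentyloxy compounds reading alike. Open, as far as these compounds go, are how a chain such as heptyl, shorter than that of compound 3, would read at this position, and whether a phenyl ring carrying an amine or a carboxylic acid would stay within the scatter of compound 2.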